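The source may report more compounds than this note shows. Statements on the series, on what has been measured and on what is new or still open speak of the compounds shown alone.

Working notes on the series, read in a functional assay on A549 cells (Homo sapiens) for inhibition, read by MTT assay, with a stated time of 72 h; on this read-out higher numbers stand for weaker inhibition and lower numbers for stronger inhibition. Going by the values given here, compound 1 `CC1=NN(c2ccccc2)C(=O)[C@@]12C(=O)C=CC[C@@H]2c1ccccc1[N+](=O)[O-]` gives 66400 nM, while compound 2 `CC1=NN(c2ccccc2)C(=O)[C@@]12C(=O)C=CC[C@@H]2c1ccc(C)cc1` gives 6570 nM, the lower of the two numbers so far. Compound 3 `CC1=NN(c2ccc(C)cc2)C(=O)[C@@]12C(=O)C=CC[C@@H]2c1ccc(C)cc1` keeps the structure of compound 2 except for one change: methyl in place of hydrogen on an aromatic carbon. In words, this is methyl in place of hydrogen on an aromatic carbon, para to a large group, which turns phenyl into 4-methylphenyl.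

Among the compounds with values here, only one measured step exists, a 10-fold lower number from compound 1 to compound 2 (1.00 log units; beyond the scatter), and it bears on this change only loosely. Within the data shown here, it sits at another place on the core, and no measured pair covers the ring altered here. Its size therefore sets no firm expectation for the new change. Among the measured compounds shown here, with a single added carbon and no direct precedent, the expectation is no step beyond the scatter in this assay, with a slight lean towards a lower number. The estimated change is a 1.2-fold lower number from compound 2 to compound 3 (0.08 log units; within the scatter). For compound 3 the expected value is 5500 nM, with an estimated range from 2000 nM to 15000 nM.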

Compound 3, half-maximal inhibitory concentration: 4320 nM
Compound 3: the middle estimate sits 1.3-fold (0.10 log units) above what was measured; the range from low to high includes it.
By their numbers in this assay, from the lowest: compounds 3 and 2 (each within the scatter of the next); then compound 1.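

In this assay, phenyl to 4-methylphenyl gives a 1.5-fold lower number from compound 2 to compound 3 (0.18 log units; within the scatter), so a methyl on this aromatic carbon, para to a large group, produces no step beyond the scatter with the 4-methylphenyl group in place on the saturated ring carbon. Going by these compounds alone, this is the first measured pair that covers this ring. The earlier step, a 10-fold lower number from compound 1 to compound 2 (1.00 log units; beyond the scatter), lies at another place on the shared core and does not speak to this ring; of the two steps now at hand, only that one lies beyond the scatter. No measurement in hand explains why this single added carbon leaves the read-out within the scatter.

Going by these compounds, a single methyl says little about the tolerance of this position as a whole, so it remains open whether a carboxylic acid, an amine, a methoxy group, chlorine or a longer chain at the same aromatic carbon would also stay within the scatter. On these data alone, it also remains open whether the phenyl to 4-methylphenyl change would read the same with the 2-nitrophenyl group of compound 1 on the saturated ring carbon.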